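H2 receptor ligands: aryl urea in place of cyclohexyl urea

The compounds below may be only part of what the source reports. "The series", "measured", "known", "first", "only" and "open" are said of these compounds alone.

Measured compounds:
- compound 1 `Cc1nc(N)sc1CCCN/C(N)=N/C(=O)NC1CCCCC1`: 170 nM
- compound 2 `Cc1nc(N)sc1CCCN/C(N)=N/C(=O)NCC(C)CCc1ccccc1`: 63.1 nM
- compound 3 `Cc1ccc(C(C)NC(=O)/N=C(\N)NCCCc2sc(N)nc2C)cc1`: 30.9 nM

In an assay on membranes from Sf9 cells for displacement of a labelled ligand from histamine H2 receptor (Homo sapiens), read by scintillation counting, with a stated time of 60 min (on this read-out lower numbers stand for stronger inhibition and higher numbers for weaker inhibition), compound 1 gives 170 nM, the highest of the three numbers recorded so far, and therefore the weakest inhibitor in this set. Compound 2 gives 63.1 nM in this assay, and compound 3 gives 30.9 nM; both of these gaps from compound 1 lie beyond the scatter, so compound 1 is clearly the least potent of the three.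

The next compound, compound 4 `Cc1nc(N)sc1CCCN/C(N)=N/C(=O)Nc1ccccc1`, has not yet been measured in this assay. Against compound 1 it carries a single change: phenyl in place of cyclohexyl on an amide-type nitrogen. Nothing else in the shared core is touched.

Within the data shown here, no step between measured compounds matches this change, so any expectation rests on the spread of the three values alone. Since compound 1 gives 170 nM and stands at the weak end of the set, there is room for the number to fall, but a shift within or just beyond the scatter seems the likeliest outcome. The step from compound 1 to compound 4 is expected to be modest, a 1.7-fold lower number from compound 1 to compound 4 (0.23 log units; within the scatter), with a downward lean. For compound 4 the estimate in this assay is 100 nM, expected to lie between 35 nM and 300 nM.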

Compound 4, inhibition constant: 3160 nM
For compound 4 the middle estimate is 32-fold (1.50 log units) below the measured one, outside the stated range (above it).
By their numbers in this assay, from the lowest: compound 3; then compound 2; then compound 1; then compound 4.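

Phenyl in place of cyclohexyl on an amide-type nitrogen gives a 19-fold higher number from compound 1 to compound 4 (1.27 log units; beyond the scatter) in this assay, so this position responds strongly to the identity of the ring, even though the two groups have the same count of heavy atoms and neither carries a hydrogen-bond donor or acceptor. Among these compounds, the earlier compounds offered no step between compounds differing in one place, so this is the first direct reading at this nitrogen, and the change it isolates is a non-aromatic ring of carbon replaced by an aromatic one. Nothing available bears on the cause of this step.

Going by these compounds, it remains open whether the weaker inhibition belongs to phenyl alone or extends to other aromatic rings on this nitrogen, such as pyridyl or a phenyl carrying a methoxy group or a chlorine. On these data alone, it is equally open whether other non-aromatic groups here, such as cyclopentyl or cycloheptyl, stay close to compound 1 at 170 nM in this assay.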